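The source may report more compounds than this note shows. Statements on the series, on what has been measured and on what is new or still open speak of the compounds shown alone.

In a functional assay on DLD-1 cells (Homo sapiens) for cytotoxicity, with a stated time of 48 h (a higher number here means a weaker inhibitor, a lower number a stronger inhibitor), compound 2 `CCCCOc1ccc2oc(/C=C/[S+](C)[O-])cc(=O)c2c1` gives 4800 nM. Among the measured compounds shown here, its only measured neighbour, compound 1 `CCCCCOc1ccc2oc(/C=C/[S+](C)[O-])cc(=O)c2c1`, gives 6600 nM. For the measured compounds named here, the one measured step, a 1.4-fold lower number from compound 1 to compound 2 (0.14 log units; within the scatter), puts hydrogen in place of methyl on a saturated chain carbon, and it stays within the scatter. On these numbers the two compounds cannot be told apart, so compound 2 stands level with compound 1.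

Compound 3 `CCCCC(=O)Oc1ccc2oc(/C=C/[S+](C)[O-])cc(=O)c2c1` differs from compound 2 by a single change: butylcarbonyl in place of butyl on an oxygen on an aromatic ring. In other words, butylcarbonyl takes the place of butyl on an oxygen on an aromatic ring.

The step of a 1.4-fold lower number from compound 1 to compound 2 (0.14 log units; within the scatter) bears on this only loosely, as it alters the far part of the chain and leaves the butoxy link untouched. Going by the values given here, no measured pair shows what butylcarbonyl in place of butyl does, so the data point to no direction. The expected change in this assay is therefore none beyond the scatter, with an estimated step of a 1.0-fold higher number from compound 2 to compound 3 (0.02 log units; within the scatter), though the uncertainty is wide. The estimate for compound 3 is 5000 nM, with an expected range from 1800 nM to 14000 nM.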

Compound 3, half-maximal inhibitory concentration: 6700 nM
For compound 3 the middle estimate is 1.3-fold (0.13 log units) below the measured one; the measured number falls inside the stated range.
By their numbers in this assay, from the lowest: compounds 2, 1 and 3 (each within the scatter of the next).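

Placing butylcarbonyl on the oxygen on an aromatic ring in place of butyl gives a 1.4-fold higher number from compound 2 to compound 3 (0.14 log units; within the scatter) in this assay, and placing it there in place of pentyl gives a 1.0-fold higher number from compound 1 to compound 3 (0.01 log units; within the scatter) in the same test. The earlier pair changed only the length of a saturated chain, whereas these steps change what is attached directly to that oxygen: a carbonyl enters, bringing a hydrogen-bond acceptor and a double bond outside aromatic rings, yet all three compounds remain within the scatter of one another. So, across these three compounds, neither chain length nor this added carbonyl separates the numbers, and no measurement shown offers a reason for that.

On these data alone, whether this position is tolerant in general stays open, since all three groups are chains of similar size, and a much shorter chain such as methyl, or a chain ending in an amine or a carboxylic acid, might behave differently. As far as these compounds go, it also remains unknown whether the same lack of separation would hold with the rest of the core changed, since every compound here shares it.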